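The compounds below may be only part of what the source reports. "The series", "measured", "known", "first", "only" and "open" are said of these compounds alone.

Measured so far:
compound 1 `COc1cccc(-c2c(C)nn(-c3nc(-c4ccc(Cl)c(Cl)c4)c(SC(C)C)s3)c2C(=O)O)c1` — in a functional assay on BJAB cells (Homo sapiens) for antiproliferative activity, with a stated time of 4 days (a lower number here means that less compound is needed, a higher number that more compound is needed for the effect), compound 1 gives 14000 nM
compound 2 `Cc1nn(-c2nc(-c3ccc(Cl)c(Cl)c3)c(SC(C)C)s2)c(C(=O)O)c1Cc1ccccc1[N+](=O)[O-]` — in this assay compound 2 gives 20000 nM

Among the compounds with values here, compound 2 holds the highest of the two numbers, but the single recorded step, a 1.4-fold higher number from compound 1 to compound 2 (0.15 log units; within the scatter), lies within the scatter, so the two compounds cannot be ranked against each other.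

Compound 3 `CCOc1ncccc1-c1c(C)nn(-c2nc(-c3ccc(Cl)c(Cl)c3)c(SC(C)C)s2)c1C(=O)O` differs from compound 2 in one place: 2-ethoxypyridin-3-yl in place of 2-nitrobenzyl on an aromatic carbon. Within the data shown here, the only step that bears on a change at this position is the one from compound 1 to compound 2, and it moved the number within the scatter despite exchanging a 3-methoxyphenyl for a 2-nitrobenzyl. Like compound 3, compound 1 carries a six-membered aromatic ring with an alkoxy substituent at this position, and compound 1 gives 14000 nM. No step beyond the scatter is therefore expected in this assay for compound 3; the estimate is 15000 nM, between 5000 nM and 45000 nM, an expected step of a 1.3-fold lower number from compound 2 to compound 3 (0.12 log units; within the scatter).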

Compound 3, half-maximal effective concentration: 11000 nM
Beside the measured number, compound 3's estimate is 1.4-fold (0.13 log units) above it, and the stated range covers the measured number.
By their numbers in this assay, from the lowest: compounds 3, 1 and 2 (each within the scatter of the next).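

At the aromatic carbon of the five-membered aromatic ring with 2 nitrogen, the third group again leaves the compounds unseparated in this assay: the exchange for 2-nitrobenzyl gives a 1.8-fold lower number from compound 2 to compound 3 (0.26 log units; within the scatter) and stays unresolved, and the exchange for 3-methoxyphenyl gives a 1.3-fold lower number from compound 1 to compound 3 (0.10 log units; within the scatter) with the same reading. This adds a six-membered aromatic ring with 1 hetero atom to the carbon-only rings seen so far, and the three compounds remain within the scatter of each other, so no group at this position can be ranked. No available evidence bears on these results.

Open, as far as these compounds go, is whether any group at this position can move the number beyond the scatter. A small group such as an amine, a hydroxy or a longer alkyl chain, which has no aromatic ring, would test this.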